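This account rests on a few compounds, and the source may have more. Where it says the series, first, only, none or still open, it means among the compounds named here.

Compound 1 `COc1cc(N2C(N)=C(C#N)C(c3ccc([N+](=O)[O-])cc3)C3=C2CC(C)(C)CC3=O)cc(OC)c1OC` sets the high mark in a functional assay on Ehrlich cells (Mus musculus) for cytotoxicity, tested at 100 ug/mL (on this read-out lower numbers stand for a weaker effect and higher numbers for a stronger effect at the one concentration tested), where compound 1 gives 80%. Compound 2 `COc1cc(N2C(N)=C(C#N)C(c3cccc([N+](=O)[O-])c3)C3=C2CC(C)(C)CC3=O)cc(OC)c1OC` gives 30% in this assay, and compound 3 `COc1cc(N2C(N)=C(C#N)C(c3ccccc3Cl)C3=C2CC(C)(C)CC3=O)cc(OC)c1OC` gives 20% in this assay. Compound 3 therefore stands lowest of the three numbers: its nearest neighbour is compound 2, a gap within the scatter, and its furthest is compound 1, a gap beyond the scatter. The measured steps were a number 50 percentage points lower from compound 1 to compound 2 (beyond the scatter), a number 60 percentage points lower from compound 1 to compound 3 (beyond the scatter) and a number 10 percentage points lower from compound 2 to compound 3 (within the scatter).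

Compound 4 `COc1cc(N2C(N)=C(C#N)C(c3ccccc3)C3=C2CC(C)(C)CC3=O)cc(OC)c1OC` differs from compound 3 in one place: hydrogen in place of chloro on an aromatic carbon. Within the data shown here, no measured step removes a group from the aryl ring in this way; the two steps that moved or replaced the nitro group were large, while the exchange of a 3-nitrophenyl for a 2-chlorophenyl stayed within the scatter. The shift from compound 3 to compound 4 is thus expected to be small, a number 2 percentage points higher from compound 3 to compound 4 (within the scatter), with no clear direction. Compound 4 is estimated to give 22% in this assay, within a range from 5% to 45%.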

Compound 4, a percentage reported as activity, at one concentration (the size of the read-out at that concentration, not a potency): 10%
Compound 4: the middle estimate sits 12 percentage points above what was measured, and the stated range covers the measured number.
By their numbers in this assay, from the lowest: compounds 4, 3 and 2 (each within the scatter of the next, the first and the last beyond it); then compound 1.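

With the unsubstituted phenyl of compound 4 as a reference in this assay, the aryl groups can now be read against hydrogen: chloro on the 2-chlorophenyl adds nothing that can be told from the scatter, with a number 10 percentage points lower from compound 3 to compound 4 (within the scatter). Nitro counts for far more in the 4-nitrophenyl than in the 3-nitrophenyl, with a number 70 percentage points lower from compound 1 to compound 4 (beyond the scatter) against a number 20 percentage points lower from compound 2 to compound 4 (beyond the scatter), so the 3-nitrophenyl keeps only a modest step over phenyl while nearly all of the high number depends on the 4-nitrophenyl. Nothing measured here accounts for these differences.

Going by these compounds, whether the high number is particular to nitro, or would also appear with an amine or a carboxylic acid on this aryl ring, remains open. A reading at one concentration also leaves the potency of these compounds unknown.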